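This account rests on a few compounds, and the source may have more. Where it says the series, first, only, none or still open, it means among the compounds named here.

Measured in an ADME assay on MT4 cells (Homo sapiens) for cytotoxicity, read by luminescence and CellTiter-Glo, with a stated time of 48 h (a lower number here means that less compound is tolerated, a higher number that more compound is tolerated), all reported as limits only:
- compound 1 `C#CC1(CO)CC(n2cc(C)c(=O)[nH]c2=O)CC1O` gives > 42000 nM as a limit
- compound 2 `Cc1cn(C2CC(O)C(C#N)(CO)C2)c(=O)[nH]c1=O` gives > 42000 nM as a limit
- compound 3 `C#CC1(CO)CC(n2cnc3c(N)nc(F)nc32)CC1O` gives > 42000 nM as a limit

Compound 3 stands at a limit of > 42000 nM and has no number. The two other values in the series are limits as well, so no rank order can be read from them.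

Compound 4 `C#CC1(CO)CC(n2cnc3c(N)nc(Cl)nc32)CC1O` differs from compound 3 in one place: chloro in place of fluoro on an aromatic carbon. The swap is chloro in place of fluoro on an aromatic carbon, between two ring nitrogen atoms.

For the measured compounds named here, no measured step covers this change. The only one available, a step that the two limits leave unreadable from compound 1 to compound 2, is cyano in place of ethynyl on a saturated ring carbon, and it has no readable size. What remains is the common ceiling: the limit of > 42000 nM in this assay, at which 3 of the 3 values shown sit. On that basis, no step beyond the scatter is expected in this assay, and a report of compound 4 as a limit is the likeliest outcome. Any readable value would lie on the lower side of that limit, meaning less compound tolerated.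

The expected change is a number no higher from compound 3 to compound 4 (the limit leaves the size open) as an estimate. For compound 4 the estimate is 42000 nM, with an expected range from 12000 nM to 84000 nM.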

Compound 4, half-maximal cytotoxic concentration: > 42000 nM
Compound 4: no number, only a limit; the forecaster's own chance of this, stated with the estimate: 75%; the middle value lies on the limit itself.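

No new step can be read from compound 3 and compound 4, which are both reported only as limits, and the series shares one ceiling: the limit of > 42000 nM in this assay, at which 4 of the 4 values shown sit. The compounds shown leave open where any of them would fall as a number in this assay, and whether chloro in place of fluoro changes that number at all.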